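A few compounds are considered here, and "the series" means these few. Any claim that something is new, unique, unknown or untested is made for them only; others in the source may bear on it.

In a functional assay on MCF7 cells (Homo sapiens) for inhibition, read by MTT assay, with a stated time of 72 h (a higher number here means a weaker inhibitor, a lower number a stronger inhibitor), compound 1 `COc1cccc(/C=C/C(=O)Nc2cc(OC)c(OC)c(OC)c2)c1` gives 27000 nM and compound 2 `COc1cc(NC(=O)/C=C/c2cccc(OCc3ccccc3)c2)cc(OC)c1OC` gives 2400 nM on the same scale. Between these two lies an 11-fold lower number from compound 1 to compound 2 (1.05 log units; beyond the scatter) for phenyl in place of hydrogen on a saturated chain carbon bound to an oxygen on an aromatic ring. Compound 3 `C=C(Br)C(=O)Nc1cccc(/C=C/C(=O)Nc2ccccc2)c1` gives 27300 nM in this assay and so sits within the scatter of compound 1 and clearly above compound 2, sharing the weak end of this small set with compound 1.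

Compound 4 `C=C(Br)C(=O)Nc1cccc(/C=C/C(=O)Nc2cccc(F)c2)c1` differs from compound 3 by fluoro in place of hydrogen on an aromatic carbon and nothing else: fluoro in place of hydrogen on an aromatic carbon, so that anilino becomes (3-fluorophenyl)amino. For the measured compounds named here, no measured step tests this change directly, because the data hold no fluoro pair. Going by the values given here, the only measured step, an 11-fold lower number from compound 1 to compound 2 (1.05 log units; beyond the scatter) in size, belongs to a different core and a far larger group than fluoro, so it offers little guidance. No step beyond the scatter is therefore expected in this assay, with at most a slight drift to a lower number. The estimated change is a 1.4-fold lower number from compound 3 to compound 4 (0.14 log units; within the scatter) and nothing more. For compound 4 the expected value is 20000 nM, with an estimated range from 7000 nM to 50000 nM.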

Compound 4, half-maximal inhibitory concentration: 3300 nM
Beside the measured number, compound 4's estimate is 6.1-fold (0.78 log units) above it, and the stated range ends above it.
By their numbers in this assay, from the lowest: compounds 2 and 4 (each within the scatter of the next); then compounds 1 and 3 (each within the scatter of the next).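

In this assay, an 8.3-fold lower number from compound 3 to compound 4 (0.92 log units; beyond the scatter) shows that this ring of the anilino group responds to substitution: one fluoro, the only difference between the two structures, moves the number beyond the scatter. For the compounds shown here, the earlier compounds could not show this, as their only step came from adding a whole phenyl on a different core, so a large group is clearly not needed for a clear change in this small set. The step rests on a single pair of compounds, and nothing in the data gives a measured reason for it.

The compounds shown leave open whether the effect belongs to fluoro itself or would also appear with a chloro, a methoxy or a nitrile at the same place, and whether fluoro on another aromatic carbon of this ring would give a step of similar size. They also leave open whether the same swap of hydrogen for fluoro would give a comparable step on a different core, rather than only on the core that compound 3 and compound 4 share.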